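Methoxyphenyl amide series: cytotoxicity on liver cells

The compounds below may be only part of what the source reports. "The series", "measured", "known", "first", "only" and "open" are said of these compounds alone.

Compound 3 `COc1ccccc1NC(=O)c1c(NCCO)cc(-c2ccc(Br)cc2)oc1=O` is one of three amides on a shared core that have been run in an ADME assay on Huh-7 cells (Homo sapiens) for cytotoxicity, with a stated time of 3 days; a higher number here means that more compound is tolerated, a lower number that less compound is tolerated. In this assay compound 3 reaches only the limit > 20000 nM, not a number. Compound 1 `O=C(Nc1ccc(Cl)cc1)c1c(NCCO)cc(-c2ccc(Br)cc2)oc1=O` likewise gives the limit > 20000 nM in this assay. Compound 2 `O=C(Nc1ccc(Br)cc1)c1c(NCCO)cc(-c2ccc(Br)cc2)oc1=O` also gives the limit > 20000 nM in this assay. Thus compound 3 stands where every measured member of the series stands, at the limit described by the limit of > 20000 nM in this assay, at which 3 of the 3 values shown sit; no compound has yet shown a readable value.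

The next compound, compound 4 `COc1cccc(NC(=O)c2c(NCCO)cc(-c3ccc(Br)cc3)oc2=O)c1`, differs from compound 3 by 3-methoxyphenyl in place of 2-methoxyphenyl on an amide-type nitrogen. The measured steps that touch the methoxyphenyl amide are a step that the two limits leave unreadable from compound 1 to compound 3 and a step that the two limits leave unreadable from compound 2 to compound 3, and the step that the two limits leave unreadable from compound 1 to compound 2 between the two halophenyl amides is equally unreadable, because all three values sit at the limit (the limit of > 20000 nM in this assay, at which 3 of the 3 values shown sit). Among the measured compounds shown here, there is therefore no measured change of size in this assay to build on, and the rearrangement of the methoxy group within the amide aryl ring has no precedent among the measured compounds.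

For compound 4 the expected value in this assay is 30000 nM, with a range from 10000 nM to 100000 nM. The step that this estimate means, a step that the limit leaves unreadable from compound 3 to compound 4, is expected to stay within the scatter, with the result most likely reported again as a limit.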

Compound 4, half-maximal cytotoxic concentration: > 20000 nM
Compound 4: only a limit was reported; the forecaster's own chance of this, stated with the estimate: 85%; the middle value lies beyond the limit too.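

In this assay compound 4 gives > 20000 nM as a limit, not a number. Its steps from compound 1, compound 2 and compound 3 cannot be read, because all four compounds sit at the same limit: the limit of > 20000 nM in this assay, at which 4 of the 4 values shown sit.

Left open is how far each of these four amides lies beyond that limit, and whether any amide on the shared core gives a readable value.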